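The source may report more compounds than this note shows. Statements on the series, on what has been measured and on what is new or still open speak of the compounds shown alone.

Measured compounds in an ADME assay on HEK293 cells (Homo sapiens) for cytotoxicity, read by MTT assay; on this read-out higher numbers stand for weaker inhibition and lower numbers for stronger inhibition:
compound 1 `Cc1cc(O)c(C(=O)/C=C/c2cccc(Br)c2)c(=O)o1`: compound 1 gives 100000 nM
compound 2 `Cc1cc(O)c(C(=O)/C=C/c2cccc(O)c2)c(=O)o1`: compound 2 gives > 100000 nM, a limit of the assay
compound 3 `Cc1ccc(/C=C/C(=O)c2c(O)cc(C)oc2=O)cc1`: compound 3 gives > 100000 nM, a limit of the assay

Compound 2 therefore stands only at a limit in this assay, with no number of its own; of the other two values shown, one further value is likewise a limit, as stated in the limit of > 100000 nM in this assay, at which 2 of the 3 values shown sit. Going by the values given here, the single step among the measured compounds that touches the same position runs a number no lower from compound 1 to compound 2 (the limit leaves the size open), where hydroxy stood in place of bromo on an aromatic carbon; its size cannot be read, only that the number did not fall.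

Compound 4 `CCOc1cccc(/C=C/C(=O)c2c(O)cc(C)oc2=O)c1` differs from compound 2 by ethyl in place of hydrogen on an oxygen on an aromatic ring. Among the compounds with values here, no measured step covers an ethyl entering on an oxygen on an aromatic ring, so the expectation rests on how little the three values shown move: two sit at the limit and the third at the same figure. Compound 4 is therefore expected to stay close to compound 2, a step of a number no higher from compound 2 to compound 4 (the limit leaves the size open), with no change beyond the scatter. Compound 4 is estimated at 100000 nM, within 50000 nM to 200000 nM, and most likely reported again only as a limit.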

Compound 4, half-maximal inhibitory concentration: 80000 nM
Estimate against measurement, compound 4: 1.3-fold (0.10 log units) above; the measured number falls inside the stated range.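

In this assay, going by these compounds alone, adding an ethyl on the oxygen on the aromatic ring gives an at least 1.2-fold lower number from compound 2 to compound 4 (0.09 log units; that floor lies within the scatter), the first step at this position with a readable floor, although the true size stays unknown and the step from compound 1 to compound 2 still cannot be read. Ethoxy in place of bromo on the aromatic carbon gives a 1.3-fold lower number from compound 1 to compound 4 (0.10 log units; within the scatter), so compound 1 and compound 4 cannot be told apart in this read-out, and this position has now taken a bromo and an ethoxy with no difference beyond the scatter. Any statement about hydroxy at this position remains bounded by the value for compound 2, which is only a limit, and the set as a whole is compressed against that same ceiling: the limit of > 100000 nM in this assay, at which 2 of the 4 values shown sit.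

The compounds shown leave open whether any group at this position can move the number beyond the scatter, since none of them carries an amine, a carboxylic acid or an alkoxy chain longer than ethoxy. They also leave open whether the same quiet behaviour would hold on a different core, as all of them share the core of compound 1.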